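This account rests on a few compounds, and the source may have more. Where it says the series, first, only, none or still open, it means among the compounds named here.

Measured in a physicochemical assay for solubility, at pH 6.8; on this read-out lower numbers stand for lower solubility and higher numbers for higher solubility:
- compound 1 `CCC(=O)N[C@@H](C)c1ccc(NC(=O)[C@H]2C[C@@H]2c2cccnc2)cc1`: 54000 nM
- compound 2 `C[C@H](NC(=O)C1CCOCC1)c1ccc(NC(=O)[C@H]2C[C@@H]2c2cccnc2)cc1`: 90000 nM
- compound 3 `C[C@H](NC(=O)c1ccc(C#N)cc1)c1ccc(NC(=O)[C@H]2C[C@@H]2c2cccnc2)cc1`: 175000 nM

Compound 3 stands level with compound 2, given a 1.9-fold higher number from compound 2 to compound 3 (0.29 log units; within the scatter), and clear of compound 1, given a 3.2-fold higher number from compound 1 to compound 3 (0.51 log units; beyond the scatter). Compound 4 `C[C@H](NC(=O)c1ccccn1)c1ccc(NC(=O)[C@H]2C[C@@H]2c2cccnc2)cc1` carries pyridin-2-yl in place of 4-cyanophenyl on a carbonyl carbon. Within the data shown here, no measured step makes this exact exchange. The nearest evidence is the other changes on that carbonyl carbon: a 1.7-fold higher number from compound 1 to compound 2 (0.22 log units; within the scatter) stayed within the scatter, and even the largest, a 3.2-fold higher number from compound 1 to compound 3 (0.51 log units; beyond the scatter), was modest. In this assay no step beyond the scatter is therefore expected, and the expected step is a 1.5-fold lower number from compound 3 to compound 4 (0.16 log units; within the scatter). Compound 4 is estimated at 120000 nM, with an expected range of 50000 nM to 280000 nM.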

Compound 4, solubility: 10000 nM
For compound 4 the middle estimate is 12-fold (1.08 log units) above the measured one; the measured number lies below the stated range.
By their numbers in this assay, from the lowest: compound 4; then compounds 1, 2 and 3 (each within the scatter of the next, the first and the last beyond it).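

In this assay, pyridin-2-yl on the carbonyl carbon gives the first step down at this position, with an 18-fold lower number from compound 3 to compound 4 (1.24 log units; beyond the scatter), a 9.0-fold lower number from compound 2 to compound 4 (0.95 log units; beyond the scatter) and a 5.4-fold lower number from compound 1 to compound 4 (0.73 log units; beyond the scatter), so the position can carry a large step. The two aromatic groups, 4-cyanophenyl and pyridin-2-yl, mark the opposite ends of the series, so an aromatic ring on this carbonyl carbon does not by itself fix the number. No evidence on the origin of this step is at hand.

Open, on these data alone, is how phenyl, pyridin-3-yl or pyridin-4-yl would read on the same carbonyl carbon. Also open, as far as these compounds go, is what an amine or a carboxylic acid on the pyridine ring would do to the number.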